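Aryl group change at the amine-linked carbon, compound 2 to 3

A few compounds are considered here, and "the series" means these few. Any claim that something is new, unique, unknown or untested is made for them only; others in the source may bear on it.

Measured so far:
compound 1 `Cc1cc(C(=O)O)ccc1C(C)N1CCC[C@H](O[C@H](CO)c2cc(Cl)cc(Cl)c2)[C@@H]1c1ccccc1` — 18000 nM
compound 2 `O=C(O)c1ccc(CN2CCC[C@H](O[C@H](CO)c3cc(Cl)cc(Cl)c3)[C@@H]2c2ccccc2)c([N+](=O)[O-])c1` — 520 nM

In an assay on isolated protein for activation of cGMP-dependent protein kinase 1 (Homo sapiens), read by ADP-Glo, with stated times of 30 min and 2 h, in the presence of a further agent that is not named here (a higher number here means that more compound is needed for the effect, a lower number that less compound is needed), compound 2 gives 520 nM, the lowest of the two numbers; compound 1 gives 18000 nM, a gap beyond the scatter. Compound 3 `Cc1nc(C(=O)O)ccc1CN1CCC[C@H](O[C@H](CO)c2cc(Cl)cc(Cl)c2)[C@@H]1c1ccccc1` is not yet measured. It differs from compound 2 as follows: a group of 10 heavy atoms (7 carbon, 1 nitrogen, 2 oxygen; one six-membered aromatic ring with 1 hetero atom) in place of a group of 12 heavy atoms (7 carbon, 1 nitrogen, 4 oxygen; one six-membered aromatic ring of carbon only), on a saturated chain carbon bound to an amine nitrogen in a ring. Going by the values given here, no step between measured compounds isolates this change, so the size of the expected step in this assay rests only on the spread between compound 1 and compound 2. Compound 3 is expected to give 3000 nM (range 800 nM to 12000 nM). The step of a 5.8-fold higher number from compound 2 to compound 3 (0.76 log units; beyond the scatter) is expected to be an increase beyond the scatter.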

Compound 3, half-maximal effective concentration: 370 nM
Estimate against measurement, compound 3: 8.1-fold (0.91 log units) above; the whole stated range lies above it.
By their numbers in this assay, from the lowest: compounds 3 and 2 (each within the scatter of the next); then compound 1.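

In this assay the swap of 4-carboxy-2-nitrophenyl for a six-membered aromatic ring with 1 hetero atom, on a saturated chain carbon bound to an amine nitrogen in a ring, gives a 1.4-fold lower number from compound 2 to compound 3 (0.15 log units; within the scatter) and so leaves the read-out unchanged within the scatter. A nitro group is therefore not required at this level, and the change of the whole group on the amine nitrogen gives a 49-fold lower number from compound 1 to compound 3 (1.69 log units; beyond the scatter) without one. Nothing measured here gives a reason for either step.

On these data alone, how an amide or a tetrazole in place of the carboxylic acid, or a longer chain on the amine nitrogen, would read in this assay remains open.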